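A few compounds are considered here, and "the series" means these few. Any claim that something is new, unique, unknown or untested is made for them only; others in the source may bear on it.

Three sulfonamides have so far been tested in an assay on isolated protein for inhibition of malate dehydrogenase, mitochondrial (Sus scrofa), with stated times of 45 min and 30 min; on this read-out higher numbers stand for weaker inhibition and lower numbers for stronger inhibition. Compound 1 `O=S(=O)(Nc1ccc(-c2nc3ccccc3o2)cc1)c1ccccc1Cl` gives > 63000 nM, which is a limit of the assay rather than a number. Compound 3 `O=S(=O)(Nc1ccc(-c2nc3ccccc3o2)cc1)c1ccccc1F` gives > 63000 nM, likewise a limit. The step that the two limits leave unreadable from compound 1 to compound 3 therefore cannot be read. Compound 2 `Cc1ccccc1S(=O)(=O)Nc1ccc2oc(-c3ccccc3)nc2c1` gives > 63000 nM, again only a limit, so it stands at the edge of what the assay can report. The untested compound 4 `COc1ccc(S(=O)(=O)Nc2ccc3oc(-c4ccccc4)nc3c2)cc1` differs from compound 2 in one place: 4-methoxyphenyl in place of 2-methylphenyl on a sulfonyl sulfur. Within the data shown here, no measured step covers this change, and the one measured step, a step that the two limits leave unreadable from compound 1 to compound 3, has no readable size. Because (the limit of > 63000 nM in this assay, at which 3 of the 3 values shown sit), nothing in the set shows a step beyond the scatter, and nothing points in either direction for the change to compound 4. Compound 4 is therefore expected to sit at the same limit, with a number no higher from compound 2 to compound 4 (the limit leaves the size open) amounting to no step beyond the scatter. The estimate for compound 4 in this assay is 63000 nM, with a range from 25000 nM to 200000 nM.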

Compound 4, half-maximal inhibitory concentration: > 63000 nM
Compound 4: a limit, no number; the forecaster's own chance of this, stated with the estimate: 85%; the middle value lies on the limit itself.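

In this assay compound 4 gives > 63000 nM, which is a limit and not a number. Among these compounds, compound 2 also gives only a limit, so no step between compound 2 and compound 4 can be read. What remains open is how strongly any compound shown inhibits the enzyme, and whether either change matters: the limit of > 63000 nM in this assay, at which 4 of the 4 values shown sit.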